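The compounds below may be only part of what the source reports. "The series", "measured", "known", "first", "only" and "open" are said of these compounds alone.

Compound 1 `COc1cc(NC(C)CCCNC(=O)Nc2cccc(F)c2)c2ncccc2c1` gives 22000 nM in a functional assay on MIA PaCa-2 cells (Homo sapiens) for inhibition, read by MTT assay, with a stated time of 72 h (on this read-out higher numbers stand for weaker inhibition and lower numbers for stronger inhibition), and compound 2 `COc1cc(NC(C)CCCNC(=O)Nc2cccc(Cl)c2)c2ncccc2c1` gives 21000 nM in this assay, so the step of a 1.0-fold lower number from compound 1 to compound 2 (0.02 log units; within the scatter) stays within the scatter. Compound 3 `COc1cc(NC(C)CCCNC(=O)NNC(=O)Nc2ccc(Cl)cc2)c2ncccc2c1` reports >= 250000 nM in this assay, which is a limit of the assay and not a number. Both steps toward it are large: an at least 11-fold higher number from compound 1 to compound 3 (1.05 log units; beyond the scatter) and an at least 11-fold higher number from compound 2 to compound 3 (1.07 log units; beyond the scatter), each sitting at the limit of >= 250000 nM in this assay, at which 1 of the 3 values shown sits. Compound 4 `COc1cc(NC(C)CCCNC(=O)NNC(=O)Nc2ccc(O)cc2)c2ncccc2c1` differs from compound 3 by hydroxy in place of chloro on an aromatic carbon. For the measured compounds named here, no measured step exchanges chloro for hydroxy; the only ring-substituent change measured, a 1.0-fold lower number from compound 1 to compound 2 (0.02 log units; within the scatter), did nothing beyond the scatter. Compound 4 is therefore expected to remain near the limit, with an estimated step of a number no higher from compound 3 to compound 4 (the limit leaves the size open). The estimate for compound 4 is 250000 nM, ranging from 60000 nM to 1000000 nM.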

Compound 4, half-maximal inhibitory concentration: 142000 nM
For compound 4 the middle estimate is 1.8-fold (0.25 log units) above the measured one; the measured number falls inside the stated range.
By their numbers in this assay, from the lowest: compounds 2 and 1 (each within the scatter of the next); then compound 4. At a limit, above all of these: compound 3.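

Hydroxy in place of chloro on this aromatic carbon, para to a large group, yields a number where chloro gave none, but an at least 1.7-fold lower number from compound 3 to compound 4 (0.24 log units; that floor lies within the scatter) is only a floor, so the size of this change stays unsettled. Compound 3 is a limit and not a number: the limit of >= 250000 nM in this assay, at which 1 of the 4 values shown sits. Compound 4 instead allows the ((4-hydroxyphenyl)carbamoyl)amino group to be sized against the smaller aryl groups, with a 6.8-fold higher number from compound 2 to compound 4 (0.83 log units; beyond the scatter) and a 6.5-fold higher number from compound 1 to compound 4 (0.81 log units; beyond the scatter). As far as these compounds go, how an amine or a carboxylic acid on this carbon would read remains open.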